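This account rests on a few compounds, and the source may have more. Where it says the series, first, only, none or still open, it means among the compounds named here.

Measured compounds:
compound 1 `Cc1ccc(NC(=S)SCC2=CCOC2=O)cc1` — in a functional assay on MCF7 cells (Homo sapiens) for antiproliferative activity, read by MTT assay, with a stated time of 72 h (on this read-out higher numbers stand for weaker inhibition and lower numbers for stronger inhibition), compound 1 gives 97400 nM
compound 2 `O=C1OCC=C1CSC(=S)NC1CC1` — in this assay compound 2 gives 94900 nM

Compound 1 holds the higher of the two numbers, but compound 2 lies within the scatter of it, so the two cannot be separated. Both sit at the weak end of the read-out. Compound 3 `O=C1OCC=C1CSC(=S)Nc1ccccc1` has not yet been measured. It differs from compound 1 by hydrogen in place of methyl on an aromatic carbon, para to a large group. Within the data shown here, no pair of measured compounds differing in one place exists, so the size of such a step is unknown here. The change is a small one, as what leaves and what enters show, and no movement beyond the scatter is expected in either direction. Compound 3 is therefore estimated at 95000 nM, with a range from 45000 nM to 200000 nM. The step of a 1.0-fold lower number from compound 1 to compound 3 (0.01 log units; within the scatter) that this estimate implies is expected to stay within the scatter.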

Compound 3, half-maximal inhibitory concentration: 89900 nM
Beside the measured number, compound 3's estimate is 1.1-fold (0.02 log units) above it; the range from low to high includes it.
By their numbers in this assay, from the lowest: compounds 3, 2 and 1 (each within the scatter of the next).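

In this assay, among these compounds, hydrogen in place of methyl on an aromatic carbon, para to a large group, gives a 1.1-fold lower number from compound 1 to compound 3 (0.03 log units; within the scatter), the first single-change step that can be read. This step lies within the scatter, so at this position the methyl and hydrogen cannot be separated, and both compounds stay at the weak end of the read-out. No measurement shown speaks to what lies behind this flat result.

The compounds shown cover only methyl and hydrogen at this position, so it remains open whether a different group there, such as an amine, a carboxylic acid or a longer chain, would move the number beyond the scatter. Whether any change to the shared core would shift the number also remains unresolved.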